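The source may report more compounds than this note shows. Statements on the series, on what has been measured and on what is new or still open speak of the compounds shown alone.

Working notes on the series. The shared core appears in compound 1 `COc1ccc(-c2cncc(C(=O)N(C)C)c2)cc1S(=O)(=O)Nc1cccc(NCCNC(=O)c2cccc(C)c2)c1`, which in a functional assay on CHO-RD-HGA16 cells for agonist activity at Orexin/Hypocretin receptor type 1 (Homo sapiens), read by fluorescence and calcium flux, with a stated time of 30 min (on this read-out higher numbers stand for an effect only at larger amounts of compound and lower numbers for an effect already at smaller amounts), gives 7530 nM. Compound 2 `COc1ccc(-c2cccc(C(=O)N(C)CCN(C)C)c2)cc1S(=O)(=O)Nc1cccc(NCCNC(=O)c2cccc(C)c2)c1` gives 638 nM in this assay. Within the data shown here, compound 3 `COc1ccc(-c2cccc(C(=O)N(C)c3ccccn3)c2)cc1S(=O)(=O)Nc1cccc(NCCNC(=O)c2cccc(C)c2)c1` returns only a limit in this assay, namely > 10000 nM; this is the limit of the assay and not a number, and compound 3 is the one member of the three that sits there (the limit of > 10000 nM in this assay, at which 1 of the 3 values shown sits). Among the measured steps, only an at least 15-fold higher number from compound 2 to compound 3 (1.19 log units; beyond the scatter) bears on the next change, and it was large.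

Compound 4 `COc1ccc(-c2cccc(C(=O)N(C)Cc3cccnc3)c2)cc1S(=O)(=O)Nc1cccc(NCCNC(=O)c2cccc(C)c2)c1` differs from compound 3 by (pyridin-3-yl)methyl in place of pyridin-2-yl on an amide-type nitrogen. The move from the dimethylaminoethyl chain to the ring-bound amide nitrogen cost potency beyond the scatter; the present change inserts one saturated carbon between the amide nitrogen and the ring while keeping a single ring nitrogen. Since compound 3 is known only as a limit, a partial return toward the value of compound 2 is expected rather than any firm gain, and the chance that compound 4 also reads as a limit remains real. The expected value for compound 4 in this assay is 3500 nM, with a range from 800 nM to 15000 nM. This expectation amounts to an at least 2.8-fold lower number from compound 3 to compound 4 (0.45 log units; beyond the scatter).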

Compound 4, half-maximal effective concentration: 460 nM
Compound 4: middle estimate off by 7.6-fold (0.88 log units), on the high side; the whole stated range lies above it.
By their numbers in this assay, from the lowest: compounds 4 and 2 (each within the scatter of the next); then compound 1. At a limit, above all of these: compound 3.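

In this assay, a ring on the amide-type nitrogen is compatible with a value in the range of compound 2 when (pyridin-3-yl)methyl takes the place of pyridin-2-yl, with an at least 21-fold lower number from compound 3 to compound 4 (1.33 log units; beyond the scatter). With a 1.4-fold lower number from compound 2 to compound 4 (0.14 log units; within the scatter), the (pyridin-3-yl)methyl group and the 2-(dimethylamino)ethyl chain cannot be told apart here, so a dimethylamino group is not required on this nitrogen for such a value. Compound 3 is known only as a limit of the assay, so that step has a bound and no exact size: the limit of > 10000 nM in this assay, at which 1 of the 4 values shown sits.

The step from pyridin-2-yl to (pyridin-3-yl)methyl changes both the link to the ring and the place of the ring nitrogen, and the two effects remain unseparated. From the compounds shown here alone, a (pyridin-2-yl)methyl or benzyl group on the same nitrogen would divide them, and the response to a longer chain such as 2-(pyridin-3-yl)ethyl remains open.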